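From 3-bromophenyl to 4-bromophenyl on a carbonyl carbon

The source may report more compounds than this note shows. Statements on the series, on what has been measured and on what is new or still open speak of the compounds shown alone.

Measured in a functional assay on DLA cells (Mus musculus) for cytotoxicity, read by LDH release, with a stated time of 48 h; a higher number here means a weaker inhibitor, a lower number a stronger inhibitor:
compound 1 (`Cc1ccc(OCC(=O)NNC(=O)c2cc3ccccc3oc2=O)c(C(=O)c2ccc(Cl)cc2)c1`) gives 60400 nM
compound 2 (`Cc1ccc(OCC(=O)NNC(=O)c2cc3ccccc3oc2=O)c(C(=O)c2cccc(Br)c2)c1`) gives 69800 nM

Compound 2 at 69800 nM stands level with compound 1 within the scatter. Compound 3 (`Cc1ccc(OCC(=O)NNC(=O)c2cc3ccccc3oc2=O)c(C(=O)c2ccc(Br)cc2)c1`) carries 4-bromophenyl in place of 3-bromophenyl on a carbonyl carbon. Within the data shown here, only one measured step bears on this: a 1.2-fold higher number from compound 1 to compound 2 (0.06 log units; within the scatter) on putting 3-bromophenyl in place of 4-chlorophenyl. On that single step, the estimated change in this assay is a 1.1-fold lower number from compound 2 to compound 3 (0.03 log units; within the scatter) and none beyond the scatter is expected in either direction. Compound 3 is estimated at 65000 nM (expected range 32000 nM to 130000 nM).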

Compound 3, half-maximal inhibitory concentration: 95300 nM
The estimate for compound 3 lay 1.5-fold (0.17 log units) below the measured number; the measured number falls inside the stated range.
By their numbers in this assay, from the lowest: compounds 1, 2 and 3 (each within the scatter of the next).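

In this assay, 4-bromophenyl in place of 3-bromophenyl on a carbonyl carbon gives a 1.4-fold higher number from compound 2 to compound 3 (0.14 log units; within the scatter), so this first comparison of where the bromine sits on the ring shows no difference beyond the scatter. Bromo in place of chloro on an aromatic carbon gives a 1.6-fold higher number from compound 1 to compound 3 (0.20 log units; within the scatter), so that exchange also stays inside the scatter. No measurement offers an explanation for these numbers.

The compounds shown leave open whether any group other than a halogen on this phenyl ring would shift the number beyond the scatter. An amine or a carboxylic acid there would put that to the test.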